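A few compounds are considered here, and "the series" means these few. Any claim that something is new, unique, unknown or untested is made for them only; others in the source may bear on it.

- compound 1 `COc1cc(NC(C)CCCNC(=O)NNC(=O)Nc2ccc(Br)cc2)c2ncccc2c1`: 27000 nM
- compound 2 `COc1cc(NC(C)CCCNC(=O)Nc2cccc(O)c2)c2ncccc2c1`: 25000 nM

In a functional assay on NCI-H460 cells (Homo sapiens) for inhibition, read by MTT assay, with a stated time of 72 h (on this read-out lower numbers stand for stronger inhibition and higher numbers for weaker inhibition), compound 2 gives 25000 nM, which sits level with compound 1 once the usual scatter is considered. Only these two measurements are available, so compound 2 has just one neighbour for comparison.

The next compound, compound 3 `COc1cc(NC(C)CCCNC(=O)NNC(=O)Nc2cccc(F)c2)c2ncccc2c1`, has ((3-fluorophenyl)carbamoyl)amino in place of 3-hydroxyphenyl on an amide-type nitrogen.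

Among the compounds with values here, one measured step bears on this change: a 1.1-fold lower number from compound 1 to compound 2 (0.03 log units; within the scatter). That step involves the same place and a closely related group, ((4-bromophenyl)carbamoyl)amino, and it stays within the scatter. Within the data shown here, no measurement yet shows what the 3-fluorophenyl group does here, so this evidence is thin.

Since the step from compound 1 was so small, no change beyond the scatter is expected. The estimated step is a 1.2-fold lower number from compound 2 to compound 3 (0.08 log units; within the scatter). For compound 3, the expected value is 21000 nM, within an estimated range of 9000 nM to 48000 nM.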

Compound 3, half-maximal inhibitory concentration: 50000 nM
For compound 3 the middle estimate is 2.4-fold (0.38 log units) below the measured one; the whole stated range lies below it.
By their numbers in this assay, from the lowest: compounds 2, 1 and 3 (each within the scatter of the next).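

In this assay, exchanging the 3-hydroxyphenyl on the amide-type nitrogen for the longer ((3-fluorophenyl)carbamoyl)amino group gives a 2.0-fold higher number from compound 2 to compound 3 (0.30 log units; within the scatter), so even this larger replacement cannot be told apart from the original group. Keeping the carbamoylamino link and exchanging the aryl group gives a 1.9-fold higher number from compound 1 to compound 3 (0.27 log units; within the scatter), which shows for the first time that a change of the ring and its halogen also stays inside the scatter, and all three compounds therefore read alike at this position. No supporting measurement is available to explain why these groups read alike.

As far as these compounds go, it remains open whether any group at this position can shift the number beyond the scatter, for example an aryl ring carrying an amine or a carboxylic acid, or a longer chain in place of the ring. These three compounds also share the same core, so they cannot show what a change there would do.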